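The source may hold more compounds than are shown below. What is called first, only, known or untested is meant among the compounds shown, and "the series" means these compounds.

In a functional assay on MCF7 cells (Homo sapiens) for cytotoxicity, read by MTT assay, with a stated time of 24 h (a lower number here means a stronger inhibitor, a higher number a weaker inhibitor), compound 1 `CCN(CC)C(=S)SCc1nc2cc(Cl)c(Cl)cc2[nH]1` gives 12600 nM, compound 2 `Cc1cc2nc(CSC(=S)N3CCN(c4ccccc4Cl)CC3)[nH]c2cc1C` gives 8390 nM, and compound 3 `CN1CCN(CCCSc2nc3ccccc3[nH]2)CC1` gives 77900 nM. Compound 3 thus has the highest of the three numbers, and both gaps separating it from the others lie beyond the usual scatter, so among these three it is the weakest inhibitor in this assay; compound 1 is its nearest neighbor and compound 2 its furthest.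

Compound 4 `c1ccc2[nH]c(SCCCN3CCNCC3)nc2c1` has not yet been measured. It differs from compound 3 in a single place: hydrogen in place of methyl on an amine nitrogen in a ring. A methyl leaves, a hydrogen enters, on an amine nitrogen in a ring of a six-membered non-aromatic ring with two nitrogens; no ring is lost and nothing else in the shared core moves.

Within the data shown here, no measured pair here shows this particular swap, so there is no step to lean on. A change this small is expected to shift the reading in this assay little, and the expected step of a 1.0-fold lower number from compound 3 to compound 4 (0.02 log units; within the scatter) is taken as none beyond the scatter. Compound 4 is accordingly expected to give about 75000 nM, within a range from 30000 nM to 190000 nM.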

Compound 4, half-maximal inhibitory concentration: 91700 nM
Compound 4: middle estimate off by 1.2-fold (0.09 log units), on the low side, and the stated range covers the measured number.
By their numbers in this assay, from the lowest: compounds 2 and 1 (each within the scatter of the next); then compounds 3 and 4 (each within the scatter of the next).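

Among these compounds, this is the only pair here that differs in one place, and in this assay hydrogen in place of methyl on the amine nitrogen in the ring gives a 1.2-fold higher number from compound 3 to compound 4 (0.07 log units; within the scatter). The reading therefore does not separate compound 3 from compound 4, so at this position the methyl makes no difference that this assay can resolve, and neither compound can be ranked above the other. Nothing available here bears on why the two readings stay together.

As far as these compounds go, the pair covers only the smallest possible change at this nitrogen, so it remains open whether a larger group there, such as a benzyl or an acetyl, would move the reading beyond the scatter. It also leaves open whether a longer chain, or an open-chain dimethylamine in place of the ring, would matter.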